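This account rests on a few compounds, and the source may have more. Where it says the series, first, only, none or still open, it means among the compounds named here.

Measured compounds:
- Compound 1 `CCC(C(=O)O)c1nn(Cc2cn3cc(OCC4CC4)c(Cl)cc3n2)c2ccccc2c1=O`: in a functional assay on CHO cells for antagonist activity at sphingosine 1-phosphate receptor 2 (Homo sapiens), read by calcium flux (a lower number here means a stronger inhibitor, a higher number a weaker inhibitor), compound 1 gives 5.6 nM
- Compound 2 `C[C@H](C(=O)O)c1nn(Cc2cn3cc(OCC4CC4)c(Cl)cc3n2)c2ccccc2c1=O`: in this assay compound 2 gives 3.2 nM

Within the data shown here, only two compounds have been measured, and they sit close together: the step of a 1.8-fold lower number from compound 1 to compound 2 (0.24 log units; within the scatter) is within the scatter, so neither compound 2 nor compound 1 stands apart from the other on the numbers so far.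

Compound 3 `CC(C(=O)O)c1nn(Cc2cn3cc(OCC4CC4)c(Cl)cc3n2)c2ccccc2c1=O` has the same atoms and bonds as compound 2; the only difference is the following: the two compounds have the same atoms and bonds; at least one stereo element is drawn with a configuration in one of them and without one in the other: 1 of 1 stereo elements differ; a stereocentre at a saturated chain carbon is drawn S in compound 2 and without a configuration in compound 3. Among the measured compounds shown here, compound 3 thus leaves the handedness at that saturated chain carbon undefined, and no measured step touches a change of this kind. For the measured compounds named here, the one measured step, from compound 1 to compound 2, concerns the length of the carboxy-bearing chain and is within the scatter, so it offers no guide beyond showing that small changes around this centre have so far made little difference.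

On that basis the step of a 1.6-fold higher number from compound 2 to compound 3 (0.19 log units; within the scatter) is expected to be small, with a modestly higher number more likely than a lower one if compound 3 holds a mixture of forms at the centre. The estimate for compound 3 is 5 nM, with a range from 2.5 nM to 12 nM.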

Compound 3, half-maximal inhibitory concentration in the sphingosine 1-phosphate receptor 2 assay: 6 nM
Beside the measured number, compound 3's estimate is 1.2-fold (0.08 log units) below it, within the range that was stated.
By their numbers in the sphingosine 1-phosphate receptor 2 assay, from the lowest: compounds 2, 1 and 3 (each within the scatter of the next).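

In the sphingosine 1-phosphate receptor 2 assay the undrawn configuration gives a 1.9-fold higher number from compound 2 to compound 3 (0.27 log units; within the scatter) and so leaves no difference that can be told from the scatter at this saturated chain carbon. The chain can now also be read on its own, since compound 1 and compound 3 are both drawn without a configuration: hydrogen in place of methyl gives a 1.1-fold higher number from compound 1 to compound 3 (0.03 log units; within the scatter) and stays within the scatter, whereas the earlier step changed the chain and the drawn configuration at once. In a physicochemical assay for lipophilicity, at pH 7.4 (a higher number here means a more lipophilic compound, a lower number a more polar compound), compound 2 gives 2.39 and compound 3 gives 2.44 as a step of a number 0.05 log units higher from compound 2 to compound 3 (within the scatter) in a pair set apart by one thing only: the fact that one of compounds 2 and 3 is drawn with a defined configuration and the other without, at the place where they differ.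

The compounds shown do not tell how the opposite configuration at this carbon would read on its own, and the drawing of compound 3 does not say what proportion of each form it holds. They also leave open what an amide or a tetrazole in place of the carboxylic acid would give in the sphingosine 1-phosphate receptor 2 assay on this same chain.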